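The compounds below may be only part of what the source reports. "The series", "measured", "known", "first", "only" and "open" are said of these compounds alone.

The study compares three compounds that share a common core and differ in the groups carried on two of their aryl rings. Compound 1 `COc1cc(C)cc(-c2c(-c3ccnc(-c4ccc(C(C)=O)cc4)c3)cnn2CC#N)c1` was measured in a functional assay on OVCAR-8 cells (Homo sapiens) for cytotoxicity, read by sulforhodamine B assay, with a stated time of 48 h, tested at 1 uM (a lower number here means a stronger effect, a higher number a weaker effect of the compound at the concentration tested), and gives 8%. Compound 2 `Cc1cc(O)cc(-c2nn(CC#N)cc2-c2ccnc(-c3ccc(Oc4ccccc4)cc3)c2)c1` gives in this assay a value of -30%. Compound 3 `COc1cc(C)cc(-c2nn(CC#N)cc2-c2ccnc(-c3ccc(N(C)C)cc3)c2)c1` gives in this assay a value of 14%, the highest of the three numbers; its value and that of compound 1 lie within the scatter of each other, whereas compound 2 sits well below it, beyond the scatter.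

Compound 4 `Cc1cc(O)cc(-c2nn(CC#N)cc2-c2ccnc(-c3ccc(N(C)C)cc3)c2)c1` has not yet been measured. It derives from compound 3 by a single change: hydrogen in place of methyl on an oxygen on an aromatic ring. Among the compounds with values here, no pair among the measured compounds differs by exactly this change, so its effect can only be inferred. Within the data shown here, compound 2, the one compound carrying the hydroxy group, gives -30%, a far lower number than compound 3, though compound 2 also differs elsewhere. A downward step from compound 3 to compound 4 of a number 19 percentage points lower from compound 3 to compound 4 (beyond the scatter) in this assay is therefore expected. Compound 4 is expected to give about -5%, within a range of -35% to 20%.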

Compound 4, a percentage reported as activity, at one concentration (the size of the read-out at that concentration, not a potency): 27%
The estimate for compound 4 lay 32 percentage points below the measured number, outside the stated range (above it).
By their numbers in this assay, from the lowest: compound 2; then compounds 1 and 3 (each within the scatter of the next); then compound 4.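

Read directly for the first time, the exchange of methoxy for hydroxy gives in this assay a number 13 percentage points higher from compound 3 to compound 4 (beyond the scatter), which means a weaker effect at the concentration tested. The hydroxy group alone therefore does not go with a low number: with hydroxy held in both compounds, dimethylamino in place of phenoxy gives a number 57 percentage points higher from compound 2 to compound 4 (beyond the scatter), so the low number of compound 2 follows the phenoxy side of the pair. Nothing at hand bears on why either step runs as it does.

The compounds shown leave open whether methoxy to hydroxy moves the number the same way when phenoxy or the acetyl-bearing group is present. They also leave open how an ethoxy group or an amine would read in place of the hydroxy group.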